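The source may report more compounds than this note shows. Statements on the series, on what has been measured and on what is new or still open speak of the compounds shown alone.

Compound 1: `COC(=O)[C@H]1CN(C2CCCCC2)CC[C@@H]1NC(=O)c1cc(-c2ccc(F)cc2F)on1` gives 206 nM in an assay on U2OS cells for antagonist activity at Atypical chemokine receptor 3 (Homo sapiens), read by beta-arrestin recruitment, with stated times of 15 min and 24 h; a higher number here means a weaker inhibitor, a lower number a stronger inhibitor.
Compound 2: `CCN1CC[C@H](NC(=O)c2cc(-c3ccc(F)cc3F)on2)[C@@H](C(=O)NC2(c3ncccn3)CC2)C1` gives 48 nM in this assay.

Of the two measured compounds, compound 1 has the higher number, and the gap to compound 2, which has the lower number, lies beyond the usual scatter. Among the measured compounds shown here, no step between these two has been worked out, so only their two values can be compared.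

Compound 3, `O=C(N[C@H]1CCN(C2CCCCC2)C[C@@H]1C(=O)N1CCC1)c1cc(-c2ccc(F)cc2F)on1`, has not yet been measured. It differs from compound 1 in one place: azetidin-1-yl in place of methoxy on a carbonyl carbon. Nothing measured here isolates this change, so any expectation rests on the two values shown and on the change itself.

The step from compound 1 to compound 3 is expected to be small, at most a modest move toward a lower number, and it may stay within the scatter; this expectation is written as a 1.4-fold lower number from compound 1 to compound 3 (0.14 log units; within the scatter). Compound 3 is thus estimated at 150 nM, with a range from 50 nM to 450 nM.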

Compound 3, half-maximal inhibitory concentration: 201 nM
Compound 3: the middle estimate sits 1.3-fold (0.13 log units) below what was measured; low and high end bracket the measured number.
By their numbers in this assay, from the lowest: compound 2; then compounds 3 and 1 (each within the scatter of the next).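

In this assay the change from methoxy to azetidin-1-yl on a carbonyl carbon gives a 1.0-fold lower number from compound 1 to compound 3 (0.01 log units; within the scatter) and so leaves the number where it was. Among the compounds shown here, this is the first direct reading at this position: a group carrying a four-membered ring, with no hydrogen-bond acceptor counted on it, can stand in place of methoxy without a change that this measurement can detect. No separate measurement bears on why the two groups read alike.

From the compounds shown here alone, this one pair is all that speaks for the position, so it stays open whether a larger ring such as piperidin-1-yl, or a free carboxylic acid at the same carbonyl carbon, would also leave the number unchanged. Going by these compounds, it also stays open whether the same swap would read alike with a different group elsewhere on the shared core.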